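Exchanging one aromatic group on a shared core

The source may hold more compounds than are shown below. What is called first, only, known or untested is meant among the compounds shown, and "the series" means these compounds.

In a functional assay on K562 cells (Homo sapiens) for inhibition, read by MTT assay, with a stated time of 48 h (on this read-out lower numbers stand for stronger inhibition and higher numbers for weaker inhibition), compound 1 `Nc1ccc(-c2cn([C@@H]3CN[C@H](C(=O)Nc4ccc(Cl)c(C(F)(F)F)c4)C3)nn2)cn1` gives 10400 nM and compound 2 `C=CC(=O)Nc1ccc(-c2cn([C@@H]3CN[C@H](C(=O)Nc4ccc(Cl)c(C(F)(F)F)c4)C3)nn2)cn1` gives 3860 nM as the lowest number of the three. Compound 3 `Nc1n[nH]c2cc(-c3cn([C@@H]4CN[C@H](C(=O)Nc5ccc(Cl)c(C(F)(F)F)c5)C4)nn3)ccc12` gives 8320 nM and so sits level with compound 1 and above compound 2. Compound 4 `Nc1nc2ccc(-c3cn([C@@H]4CN[C@H](C(=O)Nc5ccc(Cl)c(C(F)(F)F)c5)C4)nn3)nc2s1` differs from compound 3 in one group (a group of 10 heavy atoms (6 carbon, 3 nitrogen, 1 sulfur; one five-membered aromatic ring with 2 hetero atoms, one six-membered aromatic ring with 1 hetero atom) in place of a group of 10 heavy atoms (7 carbon, 3 nitrogen; one five-membered aromatic ring with 2 hetero atoms, one six-membered aromatic ring of carbon only), on an aromatic carbon). Earlier exchanges on this aromatic carbon gave a 1.3-fold lower number from compound 1 to compound 3 (0.10 log units; within the scatter) and a 2.2-fold higher number from compound 2 to compound 3 (0.33 log units; beyond the scatter) in this assay and only the second, which loses a vinylcarbonyl, goes beyond the scatter. Compound 4 involves no vinylcarbonyl, so no step beyond the scatter is expected. An estimated 1.0-fold lower number from compound 3 to compound 4 (0.02 log units; within the scatter) is what this expectation means. Compound 4 is estimated at 8000 nM with an expected range from 3500 nM to 18000 nM in this read-out.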

Compound 4, half-maximal inhibitory concentration: 26200 nM
Compound 4: the middle estimate sits 3.3-fold (0.52 log units) below what was measured; measured number outside the range, above it.
By their numbers in this assay, from the lowest: compound 2; then compounds 3 and 1 (each within the scatter of the next); then compound 4.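

In this assay this aromatic carbon proves sensitive even to an exchange between two groups of two rings with the same count of heavy atoms, with a 3.1-fold higher number from compound 3 to compound 4 (0.50 log units; beyond the scatter) and no vinylcarbonyl involved. The entering group also gives the highest number of the four, with a 2.5-fold higher number from compound 1 to compound 4 (0.40 log units; beyond the scatter) and a 6.8-fold higher number from compound 2 to compound 4 (0.83 log units; beyond the scatter) on the same carbon. No measurement at hand explains this rise.

Going by these compounds, whether a vinylcarbonyl on the amino group of compound 4 would lower its number, as on compound 1, stays open. So does how a plain phenyl or a carboxylic acid would read on this carbon.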